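The source may hold more compounds than are shown below. What is called first, only, known or untested is meant among the compounds shown, and "the series" means these compounds.

Compound 1 `O=c1cc(I)n([C@@H]2O[C@H](CO)[C@@H](O)[C@H]2O)c(=O)[nH]1`: > 50000 nM
Compound 2 `O=c1cc(NO)n([C@@H]2O[C@H](CO)[C@@H](O)[C@H]2O)c(=O)[nH]1`: > 50000 nM
Compound 3 `O=c1[nH]c(=O)n([C@@H]2O[C@H](CO)[C@@H](O)[C@H]2O)c(I)c1F`: > 50000 nM

All three were tested in a functional assay on OCI-Ly7 cells (Homo sapiens) for antiproliferative activity, read by WST assay, with a stated time of 3 days (on this read-out higher numbers stand for weaker inhibition and lower numbers for stronger inhibition), and each entry is a limit, not a number. Compound 3 therefore stands only at a limit, with no number to start from. Compound 4 `CCc1c(F)c(=O)[nH]c(=O)n1[C@@H]1O[C@H](CO)[C@@H](O)[C@H]1O` differs from compound 3 by ethyl in place of iodo on an aromatic carbon, next to the ring nitrogen and ortho to a fluoro group. Among the measured compounds shown here, two measured steps bear on this, a step that the two limits leave unreadable from compound 1 to compound 2 and a step that the two limits leave unreadable from compound 1 to compound 3. Neither has a readable size. For the measured compounds named here, with the limit of > 50000 nM in this assay, at which 3 of the 3 values shown sit, as the only evidence, no step beyond the scatter is expected in this assay, and another limit is the likeliest outcome. The expected step is a number no higher from compound 3 to compound 4 (the limit leaves the size open). Compound 4 is estimated at 50000 nM, with an expected range of 20000 nM to 100000 nM.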

Compound 4, half-maximal inhibitory concentration: 1900 nM
Compound 4: the middle estimate sits 26-fold (1.42 log units) above what was measured; the measured number lies below the stated range.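

Ethyl in place of iodo gives an at least 26-fold lower number from compound 3 to compound 4 (1.42 log units; beyond the scatter) in this assay, so a change at this position, next to the ring nitrogen and ortho to a fluoro group, can produce a readable effect. Compound 4 is the only compound here with a number, and the remaining values are limits: the limit of > 50000 nM in this assay, at which 3 of the 4 values shown sit.

The steps from compound 1 to compound 2 and from compound 1 to compound 3 cannot be read. On these data alone, it remains open whether a longer chain such as propyl, or an amine, would hold this activity at the same position. Whether ethyl needs the neighbouring fluoro group is also unresolved.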